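A few compounds are considered here, and "the series" means these few. Any claim that something is new, unique, unknown or untested is made for them only; others in the source may bear on it.

Working notes on the series. In a functional assay on MCF7 cells (Homo sapiens) for inhibition, read by fluorescence, with a stated time of 72 h (a higher number here means a weaker inhibitor of growth, a lower number a stronger inhibitor of growth), compound 1 `CCCCCCn1cnc2c(Nc3ccc(Cl)cc3)nc(N[C@H]3CC[C@H](N)CC3)nc21` gives 4200 nM and compound 2 `CCCCn1cnc2c(Nc3cc(OC)cc(OC)c3)nc(N[C@H]3CC[C@H](N)CC3)nc21` gives 4500 nM, two values within the scatter of each other. Compound 3 `CCCCn1cnc2c(Nc3ccc(Cl)cc3)nc(N[C@H]3CC[C@H](N)CC3)nc21` arises from compound 2 by 4-chlorophenyl in place of 3,5-dimethoxyphenyl on a nitrogen on an aromatic ring. Among the measured compounds shown here, no measured pair differs in one place only, so the data give no direct size for this change. For the measured compounds named here, the only guide is that compound 1 also carries 4-chlorophenyl and gives 4200 nM, a value within the scatter of that of compound 2. In this assay, no shift beyond the scatter is therefore expected, and only a slight drift towards stronger growth inhibition is estimated, with a 1.2-fold lower number from compound 2 to compound 3 (0.07 log units; within the scatter) as the expected step. For compound 3, the estimated value is 3800 nM, with an expected range of 1700 nM to 8500 nM.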

Compound 3, concentration for 50% growth inhibition: 2100 nM
Compound 3: the middle estimate sits 1.8-fold (0.26 log units) above what was measured; the range from low to high includes it.
By their numbers in this assay, from the lowest: compounds 3, 1 and 2 (each within the scatter of the next, the first and the last beyond it).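

In this assay the first direct size for 4-chlorophenyl in place of 3,5-dimethoxyphenyl on a nitrogen on an aromatic ring is a 2.1-fold lower number from compound 2 to compound 3 (0.33 log units; beyond the scatter) with nothing else altered, so this position does respond to the aryl group, though only modestly. The chain change, hydrogen in place of ethyl on a saturated chain carbon, four bonds along the chain from an aromatic nitrogen, gives a 2.0-fold lower number from compound 1 to compound 3 (0.30 log units; within the scatter) and so cannot be told apart from repeat measurement. Nothing measured here accounts for either step.

The compounds shown leave open how an unsubstituted phenyl or a 4-methoxyphenyl would read on this nitrogen, and so whether the chlorine or the loss of the two methoxy groups carries the step. On these data alone, how a methyl or a much longer chain would read also stays open.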